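The compounds below may be only part of what the source reports. "The series", "measured", "known", "first", "only" and "open" are said of these compounds alone.

This small set shares one core and the piece follows the step from compound 3 to compound 4. Compound 1 `COc1ccc(-c2c(Cl)c(=O)c3c(OC)cc(OC)cc3n2S(=O)(=O)c2ccc(OC)cc2)cc1` carries a chloro group and in a functional assay on KOPN-8 cells (Homo sapiens) for antiproliferative activity, with a stated time of 72 h (on this read-out higher numbers stand for an effect only at larger amounts of compound and lower numbers for an effect already at smaller amounts), compound 1 gives 19100 nM. Compound 2 `COc1ccc(-c2c(I)c(=O)c3c(OC)cc(OC)cc3n2S(=O)(=O)c2ccc(OC)cc2)cc1` carries iodo in place of that chloro, and in this assay compound 2 gives 8580 nM, so the step of a 2.2-fold lower number from compound 1 to compound 2 (0.35 log units; beyond the scatter) is a modest one. Compound 3 `COc1ccc(-c2cc(=O)c3c(OC)cc(OC)cc3n2S(=O)(=O)c2ccc(C#N)cc2)cc1` has no halogen and carries a cyano group on the ring joined to the sulfonyl. In this assay compound 3 is reported only as a limit, > 17200 nM, not as a number; this is the limit of > 17200 nM in this assay, at which 1 of the 3 values shown sits. Compound 4 `COc1ccc(-c2cc(=O)c3c(OC)cc(OC)cc3n2S(=O)(=O)c2ccc(OC)cc2)cc1` differs from compound 3 by methoxy in place of cyano on an aromatic carbon. No measured step bears on this exchange, since the only step shown, from compound 1 to compound 2, concerns the halogen alone. Compound 1 also carries the methoxyphenyl sulfonyl group and gives a high number, so no step beyond the scatter is expected here. Compound 4 is therefore estimated at about 20000 nM, expected between 8000 nM and 60000 nM. The expected step that the limit leaves unreadable from compound 3 to compound 4 is thus estimated to lie within the scatter.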

Compound 4, half-maximal effective concentration: > 82700 nM
Compound 4 was reported as a limit; the forecaster's own chance of this, stated with the estimate: 50%; at least 4.1-fold (0.61 log units) between middle value and limit.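

Compound 4 is reported only as a limit in this assay, and so is compound 3, so no step can be read for methoxy in place of cyano: the limit of > 82700 nM in this assay, at which 1 of the 4 values shown sits.

Among the compounds shown here, the new information concerns the aromatic carbon that holds the halogen in the earlier compounds. With hydrogen on that carbon and the (4-methoxyphenyl)sulfonyl group kept, the result is an at least 9.6-fold higher number from compound 2 to compound 4 (0.98 log units; beyond the scatter), and likewise an at least 4.3-fold higher number from compound 1 to compound 4 (0.63 log units; beyond the scatter). Among these three compounds, then, either halogen goes with a lower number than hydrogen, which the earlier chloro-to-iodo comparison alone could not show.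

The compounds shown leave open how bromo, an amine or a carboxylic acid on that carbon would read. They also leave open whether chloro or iodo there would lower the number alongside the (4-cyanophenyl)sulfonyl group.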